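Swapping 1H-benzimidazol-2-yl for 1,3-benzoxazol-2-yl in compound 2

A few compounds are considered here, and "the series" means these few. Any claim that something is new, unique, unknown or untested is made for them only; others in the source may bear on it.

Measured in a functional assay on K562 cells (Homo sapiens) for antiproliferative activity, read by MTT assay, with a stated time of 48 h; a higher number here means a weaker inhibitor, a lower number a stronger inhibitor:
Compound 1 (`N#Cc1nc2c(-c3nc4ccccc4[nH]3)c(N)n(CCO)c2nc1C#N`) gives > 50000 nM as a limit of the assay
Compound 2 (`CN(C)CCCn1c(N)c(-c2nc3ccccc3[nH]2)c2nc(C#N)c(C#N)nc21`) gives 1730 nM as a number

For the measured compounds named here, compound 2 holds the only true number so far, and its 1730 nM is the reference point. Compound 3 (`CN(C)CCCn1c(N)c(-c2nc3ccccc3o2)c2nc(C#N)c(C#N)nc21`) carries 1,3-benzoxazol-2-yl in place of 1H-benzimidazol-2-yl on an aromatic carbon. Going by the values given here, the one measured step, an at least 28-fold lower number from compound 1 to compound 2 (1.46 log units; beyond the scatter) and large, put (dimethylamino)methyl in place of hydroxy on a saturated chain carbon. It leaves the aromatic group untouched and so sets no size for this swap. In this assay the expectation is a 1.4-fold higher number from compound 2 to compound 3 (0.16 log units; within the scatter) within the scatter, leaning to a higher number. The estimate for compound 3 is 2500 nM with 700 nM to 10000 nM as its expected range.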

Compound 3, half-maximal inhibitory concentration: 5900 nM
Compound 3: the middle estimate sits 2.4-fold (0.37 log units) below what was measured; measured number inside the range.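

This first change at the aromatic carbon next to the ring atom that bears an amino group shows that the position responds in this assay: 1,3-benzoxazol-2-yl in place of 1H-benzimidazol-2-yl gives a 3.4-fold higher number from compound 2 to compound 3 (0.53 log units; beyond the scatter). The leaving group has a hydrogen-bond donor and the entering group has none, but this single swap cannot tie the step to that difference. Nothing measured here accounts for the step.

Left open is how 1,3-benzothiazol-2-yl or a plain phenyl would compare at this carbon. Also open, going by these compounds, is whether a morpholine in place of the dimethylamino group would change the size of the step.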